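A Methylthiophene Replaces a Dimethoxyphenyl on a Silent Series

A few compounds are considered here, and "the series" means these few. Any claim that something is new, unique, unknown or untested is made for them only; others in the source may bear on it.

Compound 2 `COc1ccc(CN(C(=O)Nc2ccc(Cl)c(C(F)(F)F)c2)n2cnnc2)cc1OC` has been tested in a functional assay on MDA-MB-231 cells (Homo sapiens) for cytotoxicity, read by MTT assay, with a stated time of 48 h (a higher number here means a weaker inhibitor, a lower number a stronger inhibitor), where compound 2 gives > 50000 nM, which is a limit of the assay rather than a measured number. Two close relatives stand at the same place. Compound 1 `COc1ccc(CN(C(=O)Nc2ccc(C#N)cc2)n2cnnc2)cc1OC` gives > 50000 nM in this assay, again a limit. Compound 3 `CCc1ccc(NC(=O)N(Cc2ccc(OC)c(OC)c2)n2cnnc2)cc1` gives > 50000 nM in this assay, also a limit. Going by the values given here, the one change among them that can be set side by side, a step that the two limits leave unreadable from compound 1 to compound 3, cannot be read in size because both ends rest at the limit (the limit of > 50000 nM in this assay, at which 3 of the 3 values shown sit).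

Compound 4 `Cc1ccsc1CN(C(=O)Nc1ccc(Cl)c(C(F)(F)F)c1)n1cnnc1` differs from compound 2 in a single place: 3-methylthiophen-2-yl in place of 3,4-dimethoxyphenyl on a saturated chain carbon bound to an amide-type nitrogen. Among the compounds with values here, no measured step bears on this change, and the only compared pair leaves its size unreadable. With every value shown sitting at the limit (the limit of > 50000 nM in this assay, at which 3 of the 3 values shown sit), there is no footing for a direction, so the expected step that the limit leaves unreadable from compound 2 to compound 4 is most likely nothing beyond the scatter. Compound 4 is therefore estimated at 60000 nM, within a range from 15000 nM to 200000 nM, with a real chance that only a limit is reported again.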

Compound 4, half-maximal inhibitory concentration: 29600 nM
Compound 4: middle estimate off by 2.0-fold (0.31 log units), on the high side, within the range that was stated.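

Going by these compounds alone, putting 3-methylthiophen-2-yl in place of 3,4-dimethoxyphenyl, on a saturated chain carbon bound to an amide-type nitrogen, gives the only real number so far in this assay: compound 4 reads 29600 nM. The step is an at least 1.6-fold lower number from compound 2 to compound 4 (0.22 log units; that floor lies within the scatter), and only this floor is known, since the value of compound 2 is a limit. So a value can be read with this change in place, though the size of the gain stays uncertain and most of the set remains at the limit: the limit of > 50000 nM in this assay, at which 3 of the 4 values shown sit.

From the compounds shown here alone, what stays open is whether the sulfur-containing ring, its methyl group or the loss of the two methoxy groups matters most. Also open, going by these compounds, is how this place responds to an unsubstituted phenyl or a pyridine ring, and whether 3-methylthiophen-2-yl also gives a readable value alongside the nitrile of compound 1 or the ethyl of compound 3.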